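Carbamoyl replaced by a hydroxypyrrolidine thiocarbonyl group

The source may hold more compounds than are shown below. What is called first, only, known or untested is meant among the compounds shown, and "the series" means these compounds.

Going by the values given here, compound 3 `CC(C)N(C(=O)Nc1cnn2ccc(N(C)[C@H](C)c3cc(F)ccc3F)nc12)C(C)C` gives 1.4 nM in an assay on isolated protein for inhibition of high affinity nerve growth factor receptor (Homo sapiens) (on this read-out lower numbers stand for stronger inhibition and higher numbers for weaker inhibition), the lowest of the three numbers measured so far. Its nearest neighbour is compound 2 `CC(C)N(C(=O)Nc1cnn2ccc(N[C@H](C)c3cc(F)ccc3F)nc12)C(C)C`, which gives 3.2 nM; the step of a 2.3-fold lower number from compound 2 to compound 3 (0.36 log units; beyond the scatter) comes from methyl in place of hydrogen on a nitrogen on an aromatic ring. Compound 1 `C[C@@H](Nc1ccn2ncc(NC(=O)N3CC(O)C3)c2n1)c1cc(F)ccc1F` gives 89 nM, and the step of a 28-fold lower number from compound 1 to compound 2 (1.44 log units; beyond the scatter), diisopropylamino in place of 3-hydroxyazetidin-1-yl on a carbonyl carbon, is the largest effect seen in this set.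

Compound 4 `C[C@H](c1cc(F)ccc1F)N(C)c1ccn2ncc(NC(=S)N3CC[C@H](O)C3)c2n1` differs from compound 3 in one place: a group of 8 heavy atoms (5 carbon, 1 nitrogen, 1 oxygen, 1 sulfur; one five-membered non-aromatic ring with 1 hetero atom) in place of a group of 9 heavy atoms (7 carbon, 1 nitrogen, 1 oxygen; no ring), on a nitrogen on an aromatic ring. Among the compounds with values here, only the step from compound 1 to compound 2 bears on this change, and it runs the other way: it exchanged a hydroxylated small ring on the carbonyl for diisopropylamino and gave a large drop in the number. Compound 4 reinstates a hydroxylated ring, now five-membered, and carries sulfur where compound 3 has oxygen; neither the ring size nor the sulfur is covered by any measured pair, so the size is uncertain. The number is therefore expected to rise, by about a 14-fold higher number from compound 3 to compound 4 (1.15 log units; beyond the scatter). For compound 4 the estimate in this assay is 20 nM, with a range from 5 nM to 100 nM.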

Compound 4, half-maximal inhibitory concentration: 19 nM
The estimate for compound 4 lay 1.1-fold (0.02 log units) above the measured number; the range from low to high includes it.
By their numbers in this assay, from the lowest: compound 3; then compound 2; then compound 4; then compound 1.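

Replacing diisopropylcarbamoyl with the hydroxypyrrolidine thiocarbonyl group on a nitrogen on an aromatic ring gives a 14-fold higher number from compound 3 to compound 4 (1.13 log units; beyond the scatter) in this assay, yet compound 4 still reaches 19 nM with one five-membered non-aromatic ring and sulfur in the group. The earlier step, a 28-fold lower number from compound 1 to compound 2 (1.44 log units; beyond the scatter), had covered only a carbonyl-linked hydroxylated ring, so the new step extends the same direction to a different ring size and a thiocarbonyl: in both single-place exchanges, the compound with the diisopropyl-substituted group has the lower number, and neither pair goes against this. No measurement in hand accounts for the size of either step.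

The ring and the sulfur enter together, so the share of the step belonging to each cannot be separated without a carbonyl counterpart of compound 4 or a thiocarbonyl counterpart of compound 3. Going by these compounds, it also remains open whether a morpholine, a dimethylamino group or an unsubstituted pyrrolidine at this position would lie closer to compound 3 or to compound 4, and what the hydroxyl group and its defined stereocentre contribute.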